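Swapping the Sulfonyl Aryl Ring: From Methoxy to Bromo

The source may report more compounds than this note shows. Statements on the series, on what has been measured and on what is new or still open speak of the compounds shown alone.

Compound 1, `CC(O)(C(=O)Nc1ccc(S(=O)(=O)c2ccccc2C#N)cc1)C(F)(F)F`, gives 1100 nM in a functional assay (Cavia porcellus) with sulfonylurea receptors; K-ATP channels (Homo sapiens) as the target; on this read-out higher numbers stand for weaker inhibition and lower numbers for stronger inhibition.
Compound 2, `CC(O)(C(=O)Nc1ccc(S(=O)(=O)c2ccccc2O)cc1)C(F)(F)F`, gives 3090 nM.
Compound 3, `COc1cccc(S(=O)(=O)c2ccc(NC(=O)C(C)(O)C(F)(F)F)cc2)c1`, gives 16000 nM.

Compound 3 stands highest of the three numbers in this assay, the weakest inhibitor measured here. Compound 4, `CC(O)(C(=O)Nc1ccc(S(=O)(=O)c2ccc(Br)cc2)cc1)C(F)(F)F`, differs from it by 4-bromophenyl in place of 3-methoxyphenyl on a sulfonyl sulfur. For the measured compounds named here, no measured step brings in a bromophenyl, but two steps change the ring on the sulfonyl sulfur: a 15-fold higher number from compound 1 to compound 3 (1.16 log units; beyond the scatter) and a 5.2-fold higher number from compound 2 to compound 3 (0.71 log units; beyond the scatter), both beyond the scatter. In each, the 3-methoxyphenyl of compound 3 gave the weakest inhibition seen, so replacing it is expected to lower the number, with the size uncertain. The expected step of a 3.6-fold lower number from compound 3 to compound 4 (0.55 log units; beyond the scatter) is a modest move toward stronger inhibition. Compound 4 is estimated at 4500 nM, within 1500 nM to 14000 nM.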

Compound 4, half-maximal inhibitory concentration: > 30000 nM
Compound 4: only a limit was reported; the forecaster's own chance of this, stated with the estimate: 5%; at least 6.6-fold (0.82 log units) between middle value and limit.
By their numbers in this assay, from the lowest: compound 1; then compound 2; then compound 3. At a limit, above all of these: compound 4.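

Compound 4 is reported only as a limit: the limit of > 30000 nM in this assay, at which 1 of the 4 values shown sits. Set against the two stronger compounds, 4-bromophenyl on the sulfonyl sulfur clearly loses ground: an at least 9.7-fold higher number from compound 2 to compound 4 (0.98 log units; beyond the scatter), and an at least 27-fold higher number from compound 1 to compound 4 (1.43 log units; beyond the scatter). The remaining step, an at least 1.8-fold higher number from compound 3 to compound 4 (0.27 log units; that floor lies within the scatter), does not separate 4-bromophenyl from 3-methoxyphenyl, and a ring change here need not bring stronger inhibition.

Still open, from the compounds shown here alone, is how an amine or a carboxylic acid on this ring would fare. Also open, going by these compounds, is whether any other group on the ring could match the 2-cyanophenyl of compound 1.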